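Replacing the Nitro Group: From Compound 1 to Compound 4

The compounds below may be only part of what the source reports. "The series", "measured", "known", "first", "only" and "open" are said of these compounds alone.

Compound 1 `Cc1cnc(Nc2ccc([N+](=O)[O-])cc2)nc1Nc1nc2ccccc2s1` is one of three compounds tested in a functional assay on HeLa cells (Homo sapiens) for antiproliferative activity, read by MTT assay, with a stated time of 48 h; on this read-out lower numbers stand for stronger inhibition and higher numbers for weaker inhibition. In this assay compound 1 gives 34300 nM, the highest of the three numbers. Compound 3 `Cc1ccc2nc(Nc3nc(Nc4ccc(S(C)(=O)=O)cc4)ncc3F)sc2c1` gives 17200 nM, a value that lies within the usual scatter of compound 1, so no order between the two is asserted. Compound 2 `CS(=O)(=O)c1ccc(Nc2nccc(Nc3nc4ccccc4s3)n2)cc1` gives 11300 nM, and its gap to compound 1 lies beyond the scatter.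

Compound 4 `Cc1cnc(Nc2cccc(F)c2)nc1Nc1nc2ccccc2s1` has not yet been measured. It differs from compound 1 in one place: 3-fluorophenyl in place of 4-nitrophenyl on a nitrogen on an aromatic ring. None of the measured compounds form a pair that differs in a single place, so no measured step speaks to this kind of change, and the three values together give no reason to expect a large move in either direction. The step from compound 1 to compound 4 is therefore expected to be small, a 1.4-fold lower number from compound 1 to compound 4 (0.14 log units; within the scatter), and likely within the scatter. Compound 4 is estimated at 25000 nM, with a range from 8000 nM to 80000 nM.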

Compound 4, half-maximal inhibitory concentration: 16300 nM
The estimate for compound 4 lay 1.5-fold (0.19 log units) above the measured number; the measured number falls inside the stated range.
By their numbers in this assay, from the lowest: compounds 2, 4, 3 and 1 (each within the scatter of the next, the first and the last beyond it).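

In this assay, among these compounds, 3-fluorophenyl in place of 4-nitrophenyl on a nitrogen on an aromatic ring gives a 2.1-fold lower number from compound 1 to compound 4 (0.32 log units; beyond the scatter), a modest step and the first comparison here between compounds that differ in one place. It shows that, on the core of compound 1, the nitro group can leave this position without the number rising, and that a fluorine-bearing phenyl can take its place with a small gain. No measurement available here accounts for the step.

Because two things change at once, the group and its numbered place on the phenyl ring, this single step cannot separate the loss of the nitro group from the arrival of the fluorine. Going by these compounds, how an amine or a carboxylic acid on this phenyl ring would read in this assay remains open.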